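Adding a Second Chloro Group: Three Measured, One Expected

This account rests on a few compounds, and the source may have more. Where it says the series, first, only, none or still open, it means among the compounds named here.

Of the compounds shown here, three built on two closely related cores have been tested in a functional assay on HCT-15 cells (Homo sapiens) for cytotoxicity, read by sulforhodamine B assay, with a stated time of 48 h; on this read-out higher numbers stand for lower toxicity in this test and lower numbers for higher toxicity in this test. Compound 1 `ClCc1cccc(Cn2cnc3ncnc(Cl)c32)c1` and compound 2 `ClCc1cccc(Cn2cnc3c(Cl)ncnc32)c1` are made of the same atoms joined differently; the difference between the two cores is not broken down here. In this assay compound 1 gives only a limit of the assay, > 100000 nM. Compound 2 gives 10000 nM in this assay. Compound 3 `ClCc1cccc(Cn2cnc3c(Cl)nc(Cl)nc32)c1` arises from compound 2 by chloro in place of hydrogen on an aromatic carbon. In this assay compound 3 reaches a limit of the assay, > 100000 nM. That step, an at least 10-fold higher number from compound 2 to compound 3 (1.00 log units; beyond the scatter), ends at the limit of > 100000 nM in this assay, at which 2 of the 3 values shown sit. Compound 4 `ClCc1cccc(Cn2cnc3nc(Cl)nc(Cl)c32)c1` stands to compound 1 as compound 3 stands to compound 2, arising by the same change, (chloro in place of hydrogen on an aromatic carbon). The expectation for compound 4 rests on compound 1, whose result is a limit of the assay, > 100000 nM. It also rests on the measured pair, where the number rose rather than fell, an at least 10-fold higher number from compound 2 to compound 3 (1.00 log units; beyond the scatter). Compound 4 is therefore expected to remain at or near the limit, an estimated step of a number no higher from compound 1 to compound 4 (the limit leaves the size open), and its expected value is 100000 nM, with a range from 30000 nM to 300000 nM.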

Compound 4, concentration lethal to 50% of the cells: 4570 nM
For compound 4 the middle estimate is 22-fold (1.34 log units) above the measured one; the measured number lies below the stated range.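

Swapping hydrogen for chloro on the core of compound 1 gives an at least 21-fold lower number from compound 1 to compound 4 (1.34 log units; beyond the scatter), so in this assay this change runs in the opposite direction on the two cores, and the result on one core cannot be carried over to the other: the same change on two cores in this assay, an at least 10-fold higher number (1.00 log units; beyond the scatter) from compound 2 to compound 3 and an at least 21-fold lower number (1.34 log units; beyond the scatter) from compound 1 to compound 4, at least 210-fold (2.34 log units) apart, beyond the scatter of two such steps

Compound 1 stands at a limit of the assay, > 100000 nM, so this step has a minimum size and not an exact one. The comparison rests on a single pair of compounds for each core, and it does not show why the two cores part ways or whether they would do so in another test.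

The compounds shown leave open whether a different group at this place, such as an amine or a methoxy group, would also split the two cores. They also leave open whether these results would hold with a hydroxymethyl group in place of the chloromethyl group.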